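Fluoro to Trifluoromethyl on the Ring at the Ring Nitrogen

A few compounds are considered here, and "the series" means these few. Any claim that something is new, unique, unknown or untested is made for them only; others in the source may bear on it.

Measured compounds:
Compound 1, `CC(C)(C)C1=NN(c2ccc(F)cc2)C(c2ccc(O)cc2)C1`: 95.5%
Compound 2, `CC(C)(C)C1=NN(c2ccc(C(F)(F)F)cc2)C(c2ccc(O)cc2)C1`: 94.2%
Compound 3, `CC(C)(C)C1=NN(c2cccc(F)c2)C(c2ccc(O)cc2)C1`: 98.1%

Three compounds sharing one core were tested in an assay on isolated protein for inhibition of protein kinase C zeta type (Homo sapiens), with a stated time of 4 min, tested at 62.5 uM; on this read-out lower numbers stand for less inhibition and higher numbers for more inhibition at the one concentration tested (going by the name of the read-out). In this assay compound 1 gives 95.5%, compound 2 gives 94.2% and compound 3 gives 98.1%. The step of a number 1.3 percentage points lower from compound 1 to compound 2 (within the scatter) is the change (trifluoromethyl in place of fluoro on an aromatic carbon). The step of a number 2.6 percentage points higher from compound 1 to compound 3 (within the scatter) is the change (3-fluorophenyl in place of 4-fluorophenyl on an amine nitrogen in a ring); the cores of compound 1 and compound 3 differ only in this way.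

Compound 4, `CC(C)(C)C1=NN(c2cccc(C(F)(F)F)c2)C(c2ccc(O)cc2)C1`, has not yet been measured in this assay. From compound 3 it differs by trifluoromethyl in place of fluoro on an aromatic carbon. Among the measured compounds shown here, this is the same kind of change as the one from compound 1 to compound 2, though not the same: in compound 2 the trifluoromethyl sits para to a large group, while in compound 4 it sits meta to a large group.

Given that the earlier step of a number 1.3 percentage points lower from compound 1 to compound 2 (within the scatter) stayed within the scatter, a step of similar size is expected for compound 4, namely a number 1.6 percentage points lower from compound 3 to compound 4 (within the scatter), because compound 3 already stands at 98.1%. Compound 4 is therefore estimated to give 96.5%, with a likely range from 88% to 100%.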

Compound 4, a percentage reported as inhibition, at one concentration (the size of the read-out at that concentration, not a potency): 96.1%
Estimate against measurement, compound 4: 0.4 percentage points above, and the stated range covers the measured number.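

In this assay, the step for trifluoromethyl in place of fluoro on an aromatic carbon, meta to a large group, is a number 2 percentage points lower from compound 3 to compound 4 (within the scatter), and it does not differ from the earlier step for the same change: the same change on two cores in this assay, a number 1.3 percentage points lower (within the scatter) from compound 1 to compound 2 and a number 2 percentage points lower (within the scatter) from compound 3 to compound 4, 0.7 percentage points apart, within the scatter of two such steps

Within this small set, the change therefore carries from the core of compound 1 to the core of compound 3 with no difference that stands out from the scatter. Among the compounds shown here, this does not show that the change has any real effect on the read-out, since each of the two steps lies within the scatter on its own, and their agreement rests on only two cores and on a percentage taken at one concentration, which is not a potency, so any difference in potency between the compounds would stay hidden.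

The compounds shown leave open whether the same result would hold with a nitrile or a methoxy group in place of the fluoro or trifluoromethyl group. They also leave open how the read-out would respond if an amine or a carboxylic acid took the place of the hydroxy group on the other aromatic ring.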